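The compounds below may be only part of what the source reports. "The series", "measured", "known", "first", "only" and "open" are said of these compounds alone.

Of the compounds shown here, three of one shared core have been measured so far. Compound 1 `CCC(CC)/N=c1\c(O)c(O)\c1=N/Cc1ccc(C#N)cc1` carries a pentan-3-yl group on the double-bonded nitrogen and a nitrile-bearing benzyl group; in a functional assay for inhibition, with Rattus norvegicus as the target (on this read-out lower numbers stand for stronger inhibition and higher numbers for weaker inhibition), compound 1 gives 1300 nM. Compound 2 `CC(/N=c1\c(O)c(O)\c1=N/Cc1ccc(Cl)cc1Cl)C(C)(C)C` gives 340 nM and compound 3 `CCC(C)(C)/N=c1\c(O)c(O)\c1=N/Cc1ccc(C#N)c(Cl)c1` gives 260 nM. Compound 1 therefore stands with the highest of the three numbers, and both of the other two compounds lie beyond the usual scatter from it; since compounds 2 and 3 differ from compound 1 in more than one place, their values can only be set side by side, not read as single steps.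

Compound 4 `CCCC/N=c1\c(O)c(O)\c1=N/Cc1ccc(C#N)cc1` is not yet measured. It differs from compound 1 in one place: butyl in place of pentan-3-yl on a double-bonded nitrogen. Both groups are plain alkyl chains without donors, acceptors or charge, so only a modest change is expected. The step from compound 1 to compound 4 is estimated to be a 1.5-fold higher number from compound 1 to compound 4 (0.19 log units; within the scatter), tending toward a weaker inhibition. Compound 4 is expected to give about 2000 nM, within a range from 800 nM to 5000 nM.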

Compound 4, half-maximal inhibitory concentration: > 30000 nM
Compound 4 ended at the assay's limit (the forecaster's own chance of this, stated with the estimate: 5%); at least 15-fold (1.17 log units) between middle value and limit.
By their numbers in this assay, from the lowest: compounds 3 and 2 (each within the scatter of the next); then compound 1. At a limit, above all of these: compound 4.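

Among these compounds, until this result no step between two compounds differing in one place was available, so the double-bonded nitrogen could not be read on its own; the change from pentan-3-yl to butyl gives an at least 23-fold higher number from compound 1 to compound 4 (1.36 log units; beyond the scatter). This position is therefore far from indifferent to which plain alkyl group it carries, even though neither group has hydrogen-bond donors, hydrogen-bond acceptors or net charge. In this assay, compound 4 gives > 30000 nM, which is a limit of the assay and not a number, so the full size of the step remains unknown: the limit of > 30000 nM in this assay, at which 1 of the 4 values shown sits.

From the compounds shown here alone, with only these two groups compared directly, it remains open whether a hexyl chain, a cyclopentyl ring or an aminobutyl chain on this nitrogen would give a lower number than butyl. Going by these compounds, it also remains open whether the same change would have a similar effect alongside the benzyl groups of compound 2 and compound 3.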